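The source may report more compounds than this note shows. Statements on the series, on what has been measured and on what is new or still open speak of the compounds shown alone.

Compound 3, with structure `CNC(=O)C(C)(C)C(c1ccc(Nc2ccc3ccccc3c2)cc1)n1ccnc1`, gives 12 nM in an assay on isolated protein for inhibition of cytochrome P450 26A1 (Homo sapiens), read by scintillation counting (a higher number here means a weaker inhibitor, a lower number a stronger inhibitor), the second highest of the three numbers in hand. Compound 1, `CCOC(=O)C(C)(C)C(c1ccc(Nc2ccc3ccccc3c2)cc1)n1ccnc1`, gives 0.35 nM, and compound 2, `CC(C)OC(=O)C(C)(C)C(c1ccc(Nc2ccc3ccccc3c2)cc1)n1ccnc1`, gives 290 nM, so that a 34-fold higher number from compound 1 to compound 3 (1.54 log units; beyond the scatter) and a 24-fold lower number from compound 2 to compound 3 (1.38 log units; beyond the scatter). Compound 4, `CC(C)NC(=O)C(C)(C)C(c1ccc(Nc2ccc3ccccc3c2)cc1)n1ccnc1`, carries the change (isopropyl in place of methyl on an amide-type nitrogen). The closest measured counterpart is the branching of the ester group, where an 830-fold higher number from compound 1 to compound 2 (2.92 log units; beyond the scatter), a large loss. Within the data shown here, on that basis a large step towards a weaker inhibitor is expected for compound 4 in this assay, though no measured step shows the same branching on the amide-type nitrogen. Compound 4 is therefore estimated at 500 nM, with a range of 80 nM to 5000 nM, meaning an expected step of a 42-fold higher number from compound 3 to compound 4 (1.62 log units; beyond the scatter).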

Compound 4, half-maximal inhibitory concentration: 120 nM
Compound 4: middle estimate off by 4.2-fold (0.62 log units), on the high side; the range from low to high includes it.
By their numbers in this assay, from the lowest: compound 1; then compound 3; then compound 4; then compound 2.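

In this assay, the isopropyl on the amide-type nitrogen weakens inhibition (a 10-fold higher number from compound 3 to compound 4 (1.00 log units; beyond the scatter)), a much smaller loss than that seen on branching the ester (an 830-fold higher number from compound 1 to compound 2 (2.92 log units; beyond the scatter)). With isopropyl kept on both sides, isopropylamino in place of isopropoxy gives a modest gain (a 2.4-fold lower number from compound 2 to compound 4 (0.38 log units; beyond the scatter)), while against the ethoxy group of compound 1 the same amide shows a large loss (a 340-fold higher number from compound 1 to compound 4 (2.54 log units; beyond the scatter)). No evidence in hand accounts for these differences. As far as these compounds go, whether ethylamino, a longer chain on the nitrogen or a carboxylic acid on the carbonyl carbon would approach compound 1 stays open.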